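A few compounds are considered here, and "the series" means these few. Any claim that something is new, unique, unknown or untested is made for them only; others in the source may bear on it.

Measured compounds:
Compound 1, `CS(=O)(=O)CCNc1nc(-c2ccc3ncnc(Nc4ccc5c(cnn5Cc5ccccc5)c4)c3c2)cs1`, gives 12000 nM in a functional assay on HFF cells (Homo sapiens) for inhibition; on this read-out higher numbers stand for weaker inhibition and lower numbers for stronger inhibition.
Compound 2, `CS(=O)(=O)CCNc1nc(-c2ccc3ncnc(Nc4ccc(F)c(Cl)c4)c3c2)cs1`, gives > 10000 nM in this assay.

For compound 2 only a limit is known: the limit of > 10000 nM in this assay, at which 1 of the 2 values shown sits, so no number places it on the scale. Compound 3, `CS(=O)(=O)CCNc1nc(-c2ccc3ncnc(Nc4ccc(OCc5cccc(F)c5)c(Cl)c4)c3c2)cs1`, differs from compound 2 by (3-fluorobenzyl)oxy in place of fluoro on an aromatic carbon. Going by the values given here, no step between two measured compounds exists in this set, and compound 1 also sits at weak inhibition. The step is expected to be an at least 1.4-fold lower number from compound 2 to compound 3 (0.15 log units; that floor lies within the scatter), modest toward stronger inhibition and possibly within scatter. Compound 3 is estimated at 7000 nM, between 1500 nM and 30000 nM.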

Compound 3, half-maximal inhibitory concentration: > 30000 nM
Compound 3 gave a limit, no number; the forecaster's own chance of this, stated with the estimate: 45%; at least 4.2-fold (0.63 log units) between middle value and limit.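

Going by these compounds alone, compound 2 and compound 3 both give only limits in this assay, so no step between them can be read. As far as these compounds go, whether (3-fluorobenzyl)oxy in place of fluoro shifts inhibition at all remains open.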